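A few compounds are considered here, and "the series" means these few. Any claim that something is new, unique, unknown or untested is made for them only; others in the source may bear on it.

Compound 1 `CN(C)/C=N/c1c(C=O)c(-c2ccccc2)nn1-c1ccccc1` gives 9300 nM in a functional assay on NPC-TW01 cells (Homo sapiens) for inhibition, read by MTT assay, with a stated time of 72 h; on this read-out lower numbers stand for stronger inhibition of growth and higher numbers for weaker inhibition of growth.
Compound 2 `CN(C)/C=N/c1c(C=O)c(-c2ccccc2)nn1-c1cccc(Cl)c1` gives 6400 nM in this assay.
Compound 3 `CN(C)/C=N/c1c(C=O)c(-c2ccccc2)nn1-c1ccc(Br)cc1` gives 7400 nM in this assay.

Compound 3 stands second highest of the three, with a 1.2-fold higher number from compound 2 to compound 3 (0.06 log units; within the scatter) and a 1.3-fold lower number from compound 1 to compound 3 (0.10 log units; within the scatter) both within the scatter. Compound 4 `COc1ccc(-n2nc(-c3ccccc3)c(C=O)c2/N=C/N(C)C)cc1` differs from compound 3 by methoxy in place of bromo on an aromatic carbon. For the measured compounds named here, no measured step exchanges bromo for methoxy; the steps that bear on it are the halogen additions, a 1.5-fold lower number from compound 1 to compound 2 (0.16 log units; within the scatter) and a 1.3-fold lower number from compound 1 to compound 3 (0.10 log units; within the scatter), both within the scatter. Since every substituent change so far left this assay unmoved beyond the scatter, compound 4 is expected to show a 1.1-fold higher number from compound 3 to compound 4 (0.03 log units; within the scatter), no step beyond the scatter. Compound 4 is therefore estimated at 8000 nM, within 3000 nM to 20000 nM.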

Compound 4, concentration for 50% growth inhibition: 20200 nM
Compound 4: the middle estimate sits 2.5-fold (0.40 log units) below what was measured; the measured number lies above the stated range.
By their numbers in this assay, from the lowest: compounds 2, 3 and 1 (each within the scatter of the next); then compound 4.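

In this assay this position proves not to be indifferent to what it carries: methoxy in place of bromo gives a 2.7-fold higher number from compound 3 to compound 4 (0.44 log units; beyond the scatter) and marks a real loss, and methoxy in place of hydrogen gives a 2.2-fold higher number from compound 1 to compound 4 (0.34 log units; beyond the scatter), so the loss holds against the unsubstituted ring as well. The 4-methoxyphenyl group also gives a 3.2-fold higher number from compound 2 to compound 4 (0.50 log units; beyond the scatter) against 3-chlorophenyl, leaving compound 4 the weakest inhibitor of growth of the four, whereas the halogen changes had all stayed within the scatter. Nothing measured here accounts for this shift. On these data alone, whether a hydroxy group, an amine or ethoxy at this position would move the number further stays open, as does whether methoxy would do the same where compound 2 carries its chloro.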